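The compounds below may be only part of what the source reports. "The series", "measured", "known", "first", "only" and "open" are said of these compounds alone.

Measured so far: compound 1 `C=C1C(=O)[C@H]2C[C@]1(O)CC1=C2[C@]2(C)CCCC(C)(C)[C@H]2CC1` and compound 2 `C[C@@H]1C(=O)[C@H]2C[C@]1(O)CC1=C2[C@]2(C)CCC[C@](C)(CO)[C@H]2CC1`. In a functional assay on LNCaP cells (Homo sapiens) for cytotoxicity, read by MTT assay, with a stated time of 24 h (a higher number here means a weaker inhibitor, a lower number a stronger inhibitor), compound 1 gives 2800 nM. Compound 2 gives only a limit of the assay in this assay, > 50000 nM, so compound 2 stands at the limit of > 50000 nM in this assay, at which 1 of the 2 values shown sits, and not at a number. Compound 3 `C[C@@H]1C(=O)[C@H]2C[C@]1(O)CC1=C2[C@]2(C)CCCC(C)(C)[C@H]2CC1` is not yet measured; it differs from compound 2 by hydrogen in place of hydroxy on a saturated chain carbon bound to a saturated ring carbon. Going by the values given here, no measured pair shows this change alone, so its size in this assay is unknown; a step of modest size toward stronger inhibition is expected, and the estimate means an at least 1.6-fold lower number from compound 2 to compound 3 (0.22 log units; that floor lies within the scatter). Compound 3 is expected near 30000 nM, between 8000 nM and 100000 nM.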

Compound 3, half-maximal inhibitory concentration: > 50000 nM
Compound 3 gave a limit, no number; the forecaster's own chance of this, stated with the estimate: 50%; middle value at least 1.6-fold (0.22 log units) away from the limit.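

Compound 2 and compound 3 each give only a limit, so no step can be read between them: the limit of > 50000 nM in this assay, at which 2 of the 3 values shown sit. In this assay the compounds shown leave open what hydrogen in place of hydroxy on a saturated chain carbon bound to a saturated ring carbon does.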